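Renal carcinoma cytotoxicity: dichloro in place of difluoro

The source may report more compounds than this note shows. Statements on the series, on what has been measured and on what is new or still open speak of the compounds shown alone.

Compound 3 `CN1CCN(CCCOc2cccc3nc(Nc4ccc(F)c(F)c4)ccc23)CC1` gives 18900 nM in a functional assay on cells (Panel renal (Carcinoma cell lines), Homo sapiens) for inhibition, read by sulforhodamine B assay, with a stated time of 48 h (on this read-out lower numbers stand for higher toxicity in this test and higher numbers for lower toxicity in this test), the second highest of the three numbers. Compound 2 `CN1CCN(CCCOc2cccc3nc(Nc4ccc(Cl)c(F)c4)ccc23)CC1` gives 19800 nM and compound 1 `CN1CCN(CCCOc2cccc3nc(Nc4ccc(Cl)c(C(F)(F)F)c4)ccc23)CC1` gives 6460 nM. The step of a 1.0-fold lower number from compound 2 to compound 3 (0.02 log units; within the scatter) lies within the scatter; the steps of a 3.1-fold higher number from compound 1 to compound 2 (0.49 log units; beyond the scatter) and a 2.9-fold higher number from compound 1 to compound 3 (0.47 log units; beyond the scatter) are modest. Compound 4 `CN1CCN(CCCOc2cccc3nc(Nc4cc(Cl)cc(Cl)c4)ccc23)CC1` carries the change (3,5-dichlorophenyl in place of 3,4-difluorophenyl on a nitrogen on an aromatic ring). Among the measured compounds shown here, the step from compound 2 to compound 3 bears on it most directly, as a single fluoro-for-chloro exchange, and showed nothing beyond the scatter; no measured step covers two chlorines at once. A small step in this assay toward a lower number is therefore expected, a 1.6-fold lower number from compound 3 to compound 4 (0.20 log units; within the scatter), though one within the scatter remains plausible. Compound 4 is estimated at 12000 nM, range 5000 nM to 30000 nM.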

Compound 4, concentration lethal to 50% of the cells: 17100 nM
Compound 4: middle estimate off by 1.4-fold (0.15 log units), on the low side; the measured number falls inside the stated range.
By their numbers in this assay, from the lowest: compound 1; then compounds 4, 3 and 2 (each within the scatter of the next).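

In this assay, 3,5-dichlorophenyl in place of 3,4-difluorophenyl gives a 1.1-fold lower number from compound 3 to compound 4 (0.04 log units; within the scatter) and, in place of 4-chloro-3-fluorophenyl, gives a 1.2-fold lower number from compound 2 to compound 4 (0.06 log units; within the scatter), so a second chlorine on this ring leaves the number within the scatter of both fluorinated analogues. Only the trifluoromethyl-bearing group stands apart, with a 2.6-fold higher number from compound 1 to compound 4 (0.42 log units; beyond the scatter) as the step to the new compound. Nothing shown accounts for this flat response. Still open, on these data alone, is whether unsubstituted phenyl, or a ring carrying an amine or a carboxylic acid, on the same nitrogen would shift the number.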